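Aryl variation on the thioether chain of the shared core

The source may hold more compounds than are shown below. What is called first, only, known or untested is meant among the compounds shown, and "the series" means these compounds.

Compound 3 `COc1ccc(C(C)Sc2nc3c(cnn3C)c(=O)n2-c2ccccc2)cc1` gives 352 nM in an assay on isolated protein for inhibition of aldehyde dehydrogenase 1A1 (Homo sapiens) (a lower number here means a stronger inhibitor, a higher number a weaker inhibitor), the highest number among the three measured compounds. Compound 1 `C[C@@H](Sc1nc2c(cnn2C)c(=O)n1-c1ccccc1)c1ccccc1` gives 70 nM and compound 2 `CC(Sc1nc2c(cnn2C)c(=O)n1-c1ccccc1)c1cccc(F)c1` gives 151 nM. Both measured steps raised the number modestly: a 2.2-fold higher number from compound 1 to compound 2 (0.33 log units; beyond the scatter) and a 2.3-fold higher number from compound 2 to compound 3 (0.37 log units; beyond the scatter). Compound 4 `CC(Sc1nc2c(cnn2C)c(=O)n1-c1ccccc1)c1cccnc1` differs from compound 3 by pyridin-3-yl in place of 4-methoxyphenyl on a saturated chain carbon bound to a saturated chain carbon and a sulfur. Within the data shown here, neither measured step tests a pyridin-3-yl at this carbon; they show only that exchanging the aryl group on this carbon moves the number by modest amounts. A step of comparable size, or none beyond the scatter, is therefore expected here, with no firm direction. For compound 4 the estimate is 250 nM, with a range from 80 nM to 800 nM. The expected step is a 1.4-fold lower number from compound 3 to compound 4 (0.15 log units; within the scatter).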

Compound 4, half-maximal inhibitory concentration: 139 nM
The estimate for compound 4 lay 1.8-fold (0.25 log units) above the measured number, within the range that was stated.
By their numbers in this assay, from the lowest: compounds 1, 4 and 2 (each within the scatter of the next, the first and the last beyond it); then compound 3.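

Replacing 4-methoxyphenyl with pyridin-3-yl at this carbon gives a 2.5-fold lower number from compound 3 to compound 4 (0.40 log units; beyond the scatter), so an aryl ring holding a ring nitrogen is compatible with binding in this assay. Compared with the other two aryl groups, a 1.1-fold lower number from compound 2 to compound 4 (0.04 log units; within the scatter) and a 2.0-fold higher number from compound 1 to compound 4 (0.30 log units; within the scatter), so pyridin-3-yl cannot be separated from either 3-fluorophenyl or phenyl. Nothing available explains these differences among the aryl groups.

Still open, going by these compounds, is how pyridin-2-yl or pyridin-4-yl would compare on the same carbon. Also open, on these data alone, is the effect of an amine or a carboxylic acid on the aryl ring.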